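A few compounds are considered here, and "the series" means these few. Any claim that something is new, unique, unknown or untested is made for them only; others in the source may bear on it.

Compound 1 `CCCCC[Se]c1nc(N)c2ccccc2n1` gives 90400 nM in a functional assay on MCF7 cells (Homo sapiens) for cytotoxicity, read by MTT assay, with a stated time of 72 h; a higher number here means that more compound is tolerated, a lower number that less compound is tolerated.
Compound 2 `[SeH]c1nc([SeH])c2ccccc2n1` gives > 100000 nM in this assay.

For compound 2 the value is a limit of the assay and not a number: the limit of > 100000 nM in this assay, at which 1 of the 2 values shown sits. Compound 3 `Nc1nc([SeH])nc2ccccc12` differs from compound 2 by one nitrogen atom in place of one selenium atom, on an aromatic carbon. For the measured compounds named here, no step between two measured compounds is known here, so the numbers give no direction for this change in this assay, and a step no larger than the usual scatter is expected. Compound 3 is expected to give about 120000 nM, within 40000 nM to 300000 nM. That estimate implies an expected step that the limit leaves unreadable from compound 2 to compound 3, which may again be reported only as a limit.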

Compound 3, concentration lethal to 50% of the cells: > 100000 nM
Compound 3: a limit, no number; the forecaster's own chance of this, stated with the estimate: 55%; the middle value does not contradict the limit.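

With amino in place of one selenium on the aromatic carbon, compound 3 also reads only as a limit, not a number, in this assay: the limit of > 100000 nM in this assay, at which 2 of the 3 values shown sit. The step between the two limits cannot be read, so this change has no measurable size here. Hydrogen in place of pentyl on a selenium gives an at least 1.1-fold higher number from compound 1 to compound 3 (0.04 log units; that floor lies within the scatter), so this step shows no clear change either.

From the compounds shown here alone, it remains open whether a longer chain, such as octyl, on the selenium of compound 1 would give a lower number. Going by these compounds, the effect of a carboxylic acid at that place is equally open.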